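Bromo for Chloro on a Weak Inhibitor

The compounds below may be only part of what the source reports. "The series", "measured", "known", "first", "only" and "open" are said of these compounds alone.

In a functional assay on KB cells (Homo sapiens) for inhibition (a lower number here means a stronger inhibitor, a higher number a weaker inhibitor), compound 1 `CSc1nc2c(Cl)cc(Cl)cc2n1C1O[C@H](CO)[C@@H](O)[C@H]1O` gives 270000 nM while compound 2 `Clc1nc2c(Cl)c(Cl)ccc2[nH]1` gives 80000 nM as its reading. Compound 3 `OC[C@H]1OC(n2c(Cl)nc3c(Cl)c(Cl)ccc32)[C@H](O)[C@@H]1O` has only a limit of > 100000 nM as its result, which places it among the weak inhibitors here.

Compound 4 `OC[C@H]1OC(n2c(Br)nc3c(Cl)c(Cl)ccc32)[C@H](O)[C@@H]1O` carries bromo in place of chloro on an aromatic carbon and is otherwise the same as compound 3. Among the compounds with values here, no measured pair here shows what this swap does, so the expectation rests on the change alone: no step beyond the usual scatter, in either direction, in this assay for compound 4. It may also come back as a limit. Compound 4 is estimated at 100000 nM with an expected range from 40000 nM to 220000 nM for its reading.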

Compound 4, half-maximal inhibitory concentration: > 100000 nM
Compound 4 gave a limit, no number (the forecaster's own chance of this, stated with the estimate: 55%); the middle value sits exactly at the limit.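

Compound 3 and compound 4 both end at a limit rather than a number, so no step from one to the other can be read: the limit of > 100000 nM in this assay, at which 2 of the 4 values shown sit.

On these data alone, whether bromo in place of chloro on an aromatic carbon changes inhibition in this assay stays open.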